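A few compounds are considered here, and "the series" means these few. Any claim that something is new, unique, unknown or untested is made for them only; others in the source may bear on it.

Going by the values given here, compound 3 `CCOC(=O)c1ccc(-c2ccc(N(C[C@@H](N)[C@@H](C)CC)C(=O)[C@@H]3C[C@H]3c3ccccc3)cc2)cc1` gives 260 nM in a functional assay for agonist activity at G protein-coupled receptor 88 (Homo sapiens), read by HTRF and cAMP accumulation (on this read-out higher numbers stand for an effect only at larger amounts of compound and lower numbers for an effect already at smaller amounts), the highest of the three numbers measured so far. Compound 1 `CC[C@H](C)[C@H](N)CN(C(=O)[C@@H]1C[C@H]1c1ccccc1)c1ccc(-c2ccc(COC)cc2)cc1` gives 35 nM in this assay, and compound 2 `CC[C@H](C)[C@H](N)CN(C(=O)[C@@H]1C[C@H]1c1ccccc1)c1ccc(-c2ccc(CCC(=O)OC)cc2)cc1` gives 110 nM. The unmeasured compound 4 `CC[C@H](C)[C@H](N)CN(C(=O)[C@@H]1C[C@H]1c1ccccc1)c1ccc(-c2ccc(CNC)cc2)cc1` differs from compound 3 by (methylamino)methyl in place of ethoxycarbonyl on an aromatic carbon. Among the compounds with values here, two measured steps bear on this position. The step of a 7.4-fold higher number from compound 1 to compound 3 (0.87 log units; beyond the scatter) shows that the ethoxycarbonyl group on that aromatic carbon carried the largest number of the set, while the step of a 2.4-fold higher number from compound 2 to compound 3 (0.37 log units; beyond the scatter) points the same way on a smaller scale. Both steps run toward the ester, and compound 4 removes that ester in favour of a short chain bearing a hydrogen-bond donor, closer in size to the methoxymethyl of compound 1. He therefore expects a lower number for compound 4 in this assay, with a step of about a 5.2-fold lower number from compound 3 to compound 4 (0.72 log units; beyond the scatter) expected, since compound 1 gave 35 nM with a group of similar length at the same place. His estimate for compound 4 is 50 nM, expected to fall between 15 nM and 200 nM.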

Compound 4, half-maximal effective concentration: 6400 nM
For compound 4 the middle estimate is 130-fold (2.11 log units) below the measured one, outside the stated range (above it).
By their numbers in this assay, from the lowest: compound 1; then compound 2; then compound 3; then compound 4.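

In this assay, going by these compounds alone, the change from ethoxycarbonyl to (methylamino)methyl on this aromatic carbon gives a 25-fold higher number from compound 3 to compound 4 (1.39 log units; beyond the scatter) and is a large step, whereas every step among the earlier compounds was modest. The two closer comparisons run the same way: methylamino in place of methoxy gives a 180-fold higher number from compound 1 to compound 4 (2.26 log units; beyond the scatter) and methylamino in place of (methoxycarbonyl)methyl gives a 58-fold higher number from compound 2 to compound 4 (1.76 log units; beyond the scatter) on the saturated chain carbon. At this position, compound 4 with its nitrogen-bearing group therefore stands apart from all three compounds with oxygen-bearing groups, and nothing measured here explains why.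

As far as these compounds go, it stays open whether a primary amine, a dimethylamino group or an amide at this place would behave like the (methylamino)methyl group. A carboxylic acid, or a longer chain ending in an amine, is equally uncharted.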